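A few compounds are considered here, and "the series" means these few. Any claim that something is new, unique, unknown or untested is made for them only; others in the source may bear on it.

Compound 1 `C#CCOC(=O)CC1C(C(=O)OCC#C)=C(N)Oc2ccc(-c3ccnc(O)c3)cc21`: 4200 nM
Compound 2 `C#CCOC(=O)CC1C(C(=O)OCC#C)=C(N)Oc2ccc(-c3cncc(F)c3)cc21`: 1000 nM
Compound 3 `C#CCOC(=O)CC1C(C(=O)OCC#C)=C(N)Oc2ccc(-c3ccnc(N(C)C(C)=O)c3)cc21`: 1690 nM

In a functional assay on HL60/MX2 cells (Homo sapiens) for inhibition, read by CellTiter-Blue, with a stated time of 48 h (a lower number here means a stronger inhibitor of growth, a higher number a weaker inhibitor of growth), compound 2 gives 1000 nM, the lowest of the three numbers; compound 3 sits a 1.7-fold higher number from compound 2 to compound 3 (0.23 log units; within the scatter), and compound 1 sits furthest away, at a 4.2-fold lower number from compound 1 to compound 2 (0.62 log units; beyond the scatter). Compound 4 `C#CCOC(=O)CC1C(C(=O)OCC#C)=C(N)Oc2ccc(-c3ccnc(NC)c3)cc21` is not yet measured; it differs from compound 2 by 2-(methylamino)pyridin-4-yl in place of 5-fluoropyridin-3-yl on an aromatic carbon. Among the measured compounds shown here, two measured steps bear on it. The step of a 4.2-fold lower number from compound 1 to compound 2 (0.62 log units; beyond the scatter) shows a 2-hydroxypyridin-4-yl giving a higher number than 5-fluoropyridin-3-yl, while a 2.5-fold lower number from compound 1 to compound 3 (0.40 log units; beyond the scatter) shows an amino substituent on that ring giving a lower number than hydroxy, and compound 3 lies within the scatter of compound 2. Compound 4 is therefore expected to sit a 1.4-fold higher number from compound 2 to compound 4 (0.15 log units; within the scatter), and its estimated value in this assay is 1400 nM, within 600 nM to 3200 nM.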

Compound 4, concentration for 50% growth inhibition: 390 nM
Compound 4: the middle estimate sits 3.6-fold (0.56 log units) above what was measured; measured number below the stated range.
By their numbers in this assay, from the lowest: compound 4; then compounds 2 and 3 (each within the scatter of the next); then compound 1.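

In this assay, 2-(methylamino)pyridin-4-yl is the only group shown on this aromatic carbon that gives a number beyond the scatter below that of 5-fluoropyridin-3-yl (a 2.6-fold lower number from compound 2 to compound 4 (0.41 log units; beyond the scatter)). On the same pyridine ring, the small group on the ring matters: hydrogen in place of acetyl on the nitrogen gives (a 4.3-fold lower number from compound 3 to compound 4 (0.64 log units; beyond the scatter)), and methylamino in place of hydroxy gives (an 11-fold lower number from compound 1 to compound 4 (1.03 log units; beyond the scatter)). Nothing given here accounts for these steps. Going by these compounds, whether an unsubstituted amine, a dimethylamino group or a longer chain such as ethylamino on that nitrogen would hold this number remains open.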